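The source may hold more compounds than are shown below. What is called first, only, known or untested is meant among the compounds shown, and "the series" means these compounds.

Measured compounds in this series:

compound 1 `O=C(Nc1ccc(Oc2cc(O)ncn2)cc1)Nc1cccc(C(F)(F)F)c1` — 3200 nM
compound 2 `CNc1cc(Oc2ccc(NC(=O)Nc3ccccc3)cc2)ncn1` — 6300 nM
compound 3 `CCc1cccc(NC(=O)Nc2ccc(Oc3cc(NC)ncn3)cc2)c1` — 200 nM

In an assay on isolated protein for inhibition of serine/threonine-protein kinase TNNI3K (Homo sapiens) (on this read-out higher numbers stand for weaker inhibition and lower numbers for stronger inhibition), compound 1 gives 3200 nM, the second highest of the three numbers. Compound 2, at 6300 nM, lies within the scatter of compound 1; compound 3, at 200 nM, stands well beyond it. Within the data shown here, the single one-place step in the set is a 32-fold lower number from compound 2 to compound 3 (1.50 log units; beyond the scatter), an ethyl in place of hydrogen on an aromatic carbon of the urea-side ring, so it concerns a different part of the molecule from the change considered here.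

Compound 4 `CC(=O)Nc1cc(Oc2ccc(NC(=O)Nc3cccc(C(F)(F)F)c3)cc2)ncn1` differs from compound 1 by acetamido in place of hydroxy on an aromatic carbon, on an aromatic carbon of a six-membered aromatic ring with two nitrogen, the position reading as 6-hydroxypyrimidin-4-yl to 6-acetamidopyrimidin-4-yl. Among the measured compounds shown here, no measured step touches this position: compounds 1 and 2 differ there but also at the trifluoromethyl, so their values alone cannot be split into two contributions. The step is therefore expected to be small, in either direction, and most likely within the scatter. The estimated step is a 1.6-fold lower number from compound 1 to compound 4 (0.20 log units; within the scatter). Compound 4 is expected to give about 2000 nM in this assay, within 500 nM to 8000 nM.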

Compound 4, half-maximal inhibitory concentration: 20 nM
Beside the measured number, compound 4's estimate is 100-fold (2.00 log units) above it, outside the stated range (below it).
By their numbers in this assay, from the lowest: compound 4; then compound 3; then compounds 1 and 2 (each within the scatter of the next).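

In this assay, among these compounds, the change from hydroxy to acetamido next to the ring nitrogen gives a 160-fold lower number from compound 1 to compound 4 (2.20 log units; beyond the scatter); the rest of the molecule, including the trifluoromethyl, stays the same, so the whole step belongs to this position, which the earlier compounds could not isolate. The position is therefore highly sensitive to this change and accepts the larger group, with 4 heavy atoms in acetamido against 1 in hydroxy. Both groups count 1 hydrogen-bond donor and 1 hydrogen-bond acceptor, so those counts do not separate them, and nothing available here accounts for the size of the step.

This single pair leaves open which part of acetamido goes with the step, since a plain amine or a longer acyl chain such as propanamido on the same core would be needed to separate the nitrogen, the carbonyl and the chain length. From the compounds shown here alone, it also remains open whether the same step would hold with the ethyl-bearing or unsubstituted urea-side ring in place of the trifluoromethyl-bearing one.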